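This account rests on a few compounds, and the source may have more. Where it says the series, first, only, none or still open, it means among the compounds named here.

Measured in an in vitro ADME assay on microsomes from liver (Homo sapiens) for metabolic stability; a higher number here means faster removal of the compound, a lower number slower removal:
Compound 1 `Cc1ccc(Cn2c(=O)[nH]c3c(N)nc(-c4ncco4)cc32)cn1`: < 7 mL.min-1.g-1 (a limit)
Compound 2 `Cc1ccc(Cn2c(=O)[nH]c3c(N)nc(C(F)(F)F)cc32)nn1`: < 8 mL.min-1.g-1 (a limit)
Compound 3 `Cc1cccc(Cn2c(=O)[nH]c3c(N)nc(C(F)(F)F)cc32)n1`: < 8 mL.min-1.g-1 (a limit)

Compound 2 has no exact number. Its result of < 8 mL.min-1.g-1 is a limit of the assay, and the other two results are limits as well. It sits at the limit of < 8 mL.min-1.g-1 in this assay, at which 2 of the 3 values shown sit.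

Compound 4 `Cc1cc(Cn2c(=O)[nH]c3c(N)nc(C(F)(F)F)cc32)no1` keeps the core of compound 2 and changes one group: 5-methyl-1,2-oxazol-3-yl in place of 6-methylpyridazin-3-yl on a saturated chain carbon bound to an aromatic nitrogen.

Among the compounds with values here, the one measured step that bears on this change is a step that the two limits leave unreadable from compound 2 to compound 3. That step also swaps the ring on a saturated chain carbon bound to an aromatic nitrogen, but its size cannot be read, so it offers no sign of a direction.

No step beyond the usual scatter is therefore expected in this assay. The expected step is a number no lower from compound 2 to compound 4 (the limit leaves the size open). For compound 4 the estimate is 8 mL.min-1.g-1, with an expected range of 5 mL.min-1.g-1 to 15 mL.min-1.g-1.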

Compound 4, intrinsic clearance in microsomes: < 8 mL.min-1.g-1
Compound 4 ended at the assay's limit (the forecaster's own chance of this, stated with the estimate: 65%); the middle value lies on the limit itself.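

In this assay compound 4 gives < 8 mL.min-1.g-1, which is a limit and not an exact number. The results of compound 2 and compound 3 are limits too, so the steps from either one to compound 4 cannot be read. The compounds shown leave open how fast each is actually removed, and whether swapping the ring changes that at all.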